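Amine swap on ester and amide pair: expectation for compound 4

This account rests on a few compounds, and the source may have more. Where it says the series, first, only, none or still open, it means among the compounds named here.

Three members of the series have a number in an ADME assay on HEK-293T cells (Homo sapiens) for cytotoxicity, read by MTT assay, with a stated time of 48 h; a higher number here means that more compound is tolerated, a lower number that less compound is tolerated. Compound 1 `CC1CCN(CCCC(=O)O[C@@H]2C[C@@H]3CC[C@@]2(C)C3(C)C)CC1` gives 171000 nM in this assay. Compound 2 `CCN1CCN(CCCC(=O)O[C@@H]2C[C@@H]3CC[C@@]2(C)C3(C)C)CC1` gives 131000 nM in this assay. Compound 3 `CCN1CCN(CCCC(=O)N[C@@H]2C[C@H]3CC[C@]2(C)C3(C)C)CC1` gives 268000 nM in this assay; its gap to compound 2 is beyond the scatter, while its gap to compound 1 is within it, so no order between compound 3 and compound 1 is claimed.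

Compound 2 and compound 1 differ by one change, (4-methylpiperidin-1-yl in place of 4-ethylpiperazin-1-yl on a saturated chain carbon, three bonds along the chain from a carbonyl carbon). That change produced a 1.3-fold higher number from compound 2 to compound 1 (0.12 log units; within the scatter), a step that does not rise out of the noise of repeated runs. Compound 2 and compound 3 share the amine part but differ in their cores; the difference between the two cores is not broken down here.

Compound 4 `CC1CCN(CCCC(=O)N[C@@H]2C[C@H]3CC[C@]2(C)C3(C)C)CC1` has not yet been run in this assay. It differs from compound 3 by 4-methylpiperidin-1-yl in place of 4-ethylpiperazin-1-yl on a saturated chain carbon, three bonds along the chain from a carbonyl carbon, the same change as from compound 2 to compound 1, at the same place word for word. For the measured compounds named here, with a single precedent, the expected step is small and uncertain in direction: a 1.2-fold higher number from compound 3 to compound 4 (0.08 log units; within the scatter) is estimated because a 1.3-fold higher number from compound 2 to compound 1 (0.12 log units; within the scatter) was the only outcome of this change seen so far. Compound 4 is therefore expected to give about 320000 nM in this assay, with a likely range from 180000 nM to 560000 nM.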

Compound 4, half-maximal cytotoxic concentration: 142000 nM
For compound 4 the middle estimate is 2.3-fold (0.35 log units) above the measured one; the whole stated range lies above it.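

On the core of compound 3, 4-methylpiperidin-1-yl in place of 4-ethylpiperazin-1-yl in this assay gives a small step (a 1.9-fold lower number from compound 3 to compound 4 (0.28 log units; within the scatter)), and this step does not rise out of the noise of repeated runs. The change can therefore be carried from the core of compound 2 to the core of compound 3 without a step beyond the scatter on either core, which is all that this pair of steps supports; it fixes no direction for the change, and a constant effect of the change on both cores is not demonstrated either. The two steps point opposite ways on paper, yet they cannot be told apart, so no dependence of the change on the core can be claimed: the same change on two cores in this assay, a 1.3-fold higher number (0.12 log units; within the scatter) from compound 2 to compound 1 and a 1.9-fold lower number (0.28 log units; within the scatter) from compound 3 to compound 4, 2.5-fold (0.39 log units) apart, within the scatter of two such steps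

On these data alone, whether any amine gives a step beyond the scatter on these cores remains open, for example morpholin-4-yl, piperidin-1-yl without the methyl group, or dimethylamino in place of the present rings. Also open, as far as these compounds go, is whether a longer chain between the amine and the carbonyl would move the number in this assay on either core, or would leave the two cores as close as they stand here.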